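The source may hold more compounds than are shown below. What is called first, only, known or untested is meant among the compounds shown, and "the series" means these compounds.

In an assay on HEK293 cells for antagonist activity at Voltage-dependent L-type calcium channel subunit alpha-1C (Oryctolagus cuniculus), read by FLIPR (on this read-out higher numbers stand for weaker inhibition and lower numbers for stronger inhibition), compound 1, `COC(=O)C1=C(C(C)C)NC(=O)NC1c1cccc([N+](=O)[O-])c1`, gives > 100000 nM, which is a limit of the assay rather than a number. Compound 2, `COC(=O)C1=C(C(C)C)NC(=O)N(C(=O)OC(C)C)C1c1cccc([N+](=O)[O-])c1`, carries isopropoxycarbonyl in place of hydrogen on an amide-type nitrogen in a ring and in this assay gives 10400 nM. As far as these compounds go, that change produced the step of an at least 9.6-fold lower number from compound 1 to compound 2 (0.98 log units; beyond the scatter), and how large it truly is stays open because of the limit of > 100000 nM in this assay, at which 1 of the 3 values shown sits. For the measured compounds named here, a second core appears in compound 3, `COC(=O)C1=C(C)N=C(SC)NC1c1cccc([N+](=O)[O-])c1`, which in this assay gives 3290 nM, the lowest of the two numbers measured so far. The difference between the core of compound 1 and the core of compound 3 is not broken down here.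

Compound 4, `COC(=O)C1=C(C)N=C(SC)N(C(=O)OC(C)C)C1c1cccc([N+](=O)[O-])c1`, has not yet been measured. It carries isopropoxycarbonyl in place of hydrogen on an amine nitrogen in a ring. Going by the values given here, this is the same kind of change as the one seen between compound 1 and compound 2, but not the same: there the new group sat on an amide-type nitrogen, with the ring atom that bears an isopropyl group three ring bonds away, whereas here it sits on an amine nitrogen, next to the ring atom that bears a methylsulfanyl group, with the ring atom that bears a methyl group three ring bonds away. On the strength of the earlier step, an at least 9.6-fold lower number from compound 1 to compound 2 (0.98 log units; beyond the scatter), the change is expected to lower the number for compound 4 as well, though the different surroundings of the nitrogen leave the size uncertain. In this assay the expected step is an 11-fold lower number from compound 3 to compound 4 (1.04 log units; beyond the scatter). The estimate for compound 4 in this assay is 300 nM, expected to fall between 50 nM and 2000 nM.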

Compound 4, half-maximal inhibitory concentration: 16100 nM
Compound 4: middle estimate off by 54-fold (1.73 log units), on the low side; the measured number lies above the stated range.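

In this assay, putting isopropoxycarbonyl in place of hydrogen on an amine nitrogen in a ring gave a 4.9-fold higher number from compound 3 to compound 4 (0.69 log units; beyond the scatter), whereas on the amide-type nitrogen of the other core the same group gave an at least 9.6-fold lower number from compound 1 to compound 2 (0.98 log units; beyond the scatter). The group therefore moved the number in opposite directions on the two cores, so the result from one core could not be carried over to the other in this series: the same change on two cores in this assay, an at least 9.6-fold lower number (0.98 log units; beyond the scatter) from compound 1 to compound 2 and a 4.9-fold higher number (0.69 log units; beyond the scatter) from compound 3 to compound 4, at least 47-fold (1.67 log units) apart, beyond the scatter of two such steps This pair of steps does not show why the direction reversed, nor does it give a rule for other cores, and the true size of the first step stays unknown: the limit of > 100000 nM in this assay, at which 1 of the 4 values shown sits.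

The core of compound 1 and the core of compound 3 differ in more than one place, so the compounds shown leave open which of those differences goes with the reversal; a core that changes only the methylsulfanyl group or only the isopropyl group would be needed to separate them. They also leave open whether another group on the same nitrogen, such as acetyl or a longer chain like butoxycarbonyl, would follow the step seen with isopropoxycarbonyl on either core.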